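Adding two methyl groups to the piperazine of compound 2

The source may hold more compounds than are shown below. What is called first, only, known or untested is meant among the compounds shown, and "the series" means these compounds.

In an ADME assay on microsomes from liver (Rattus norvegicus) for metabolic stability, read by LC-MS, using NADPH, with a stated time of 60 min, tested at 0.1 uM (a higher number here means that more of the compound is left, a lower number that less of the compound is left), compound 1 `Fc1ccc(Nc2cc3[nH]c(Nc4ccc(N5CCNCC5)cn4)nc3cn2)cc1C(F)(F)F` gives 59% and compound 2 `Fc1ccc(Nc2cc3[nH]c(Nc4ccc(N5CCNCC5)cn4)nc3cn2)cc1F` gives 73%, the higher of the two numbers. Among the compounds with values here, the only measured step, a number 14 percentage points higher from compound 1 to compound 2 (beyond the scatter), is fluoro in place of trifluoromethyl on an aromatic carbon. It concerns a different place in the molecule, so it gives no direct guide to the next change. Compound 3 `C[C@@H]1CN(c2ccc(Nc3nc4cnc(Nc5ccc(F)c(F)c5)cc4[nH]3)nc2)C[C@H](C)N1` differs from compound 2 as follows: 3,5-dimethylpiperazin-1-yl in place of piperazin-1-yl on an aromatic carbon. Within the data shown here, with no measured step at this place, the expected change in this assay is none beyond the scatter: a number 1 percentage points lower from compound 2 to compound 3 (within the scatter). For compound 3 the estimated value is 72%, within an expected range from 52% to 88%.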

Compound 3, percent of the compound remaining: 66%
Estimate against measurement, compound 3: 6 percentage points above; measured number inside the range.
By their numbers in this assay, from the lowest: compounds 1, 3 and 2 (each within the scatter of the next, the first and the last beyond it).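

In this assay, the first step measured at this position, 3,5-dimethylpiperazin-1-yl in place of piperazin-1-yl on an aromatic carbon, gives a number 7 percentage points lower from compound 2 to compound 3 (within the scatter), so the two added methyl groups and two defined stereocentres leave compound 3 indistinguishable from compound 2 here. The position therefore accepts this larger ring substituent without a change that can be told from the scatter. Nothing available bears on the reason for this result. Still open, from the compounds shown here alone, is how a morpholine ring or an open-chain amine would behave at this position. Also open, going by these compounds, is whether the 3,5-dimethylpiperazin-1-yl group would give the same result alongside the trifluoromethyl group of compound 1.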